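A few compounds are considered here, and "the series" means these few. Any claim that something is new, unique, unknown or untested is made for them only; others in the source may bear on it.

Going by the values given here, compound 1 `COc1ccc(-c2cc(/C=C/C(=O)c3ccc(N)cc3)[nH]n2)cc1` and compound 2 `COc1cc(-c2cc(/C=C/C(=O)c3ccc(N)cc3)[nH]n2)cc(OC)c1OC` are the two measured members of this set. In a functional assay on HT-29 cells (Homo sapiens) for inhibition, read by sulforhodamine B assay, with a stated time of 48 h (a lower number here means a stronger inhibitor of growth, a higher number a weaker inhibitor of growth), compound 1 gives 2750 nM. In this assay compound 2 gives 1850 nM, the lower of the two numbers, though its gap to compound 1 lies within the scatter, so neither compound can be called the stronger growth inhibitor. Compound 3 `COc1ccc(C(=O)/C=C/c2cc(-c3cc(OC)c(OC)c(OC)c3)n[nH]2)cc1` has not yet been measured. Relative to compound 2 the change is methoxy in place of amino on an aromatic carbon. Among the compounds with values here, no measured pair in this set shares this change, so nothing in the data sizes it; the step from compound 2 to compound 3 is expected to be small, a 1.4-fold higher number from compound 2 to compound 3 (0.13 log units; within the scatter), and not clearly beyond the scatter in either direction. Compound 3 is therefore estimated at 2500 nM in this assay, with a range from 800 nM to 8000 nM.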

Compound 3, concentration for 50% growth inhibition: 1970 nM
The estimate for compound 3 lay 1.3-fold (0.10 log units) above the measured number; low and high end bracket the measured number.
By their numbers in this assay, from the lowest: compounds 2, 3 and 1 (each within the scatter of the next).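

Going by these compounds alone, compound 2 and compound 3 form the first measured pair in this set that differs at this position, and in this assay the exchange of 4-aminophenyl for 4-methoxyphenyl gives a 1.1-fold higher number from compound 2 to compound 3 (0.03 log units; within the scatter). Within the data shown here, the change therefore has a measured size for the first time, and it does not separate the two compounds. In this one pair, replacing the amino group, which has a hydrogen-bond donor, with methoxy, which has none, leaves the growth-inhibition number within the scatter.

As far as these compounds go, whether other groups at this place, such as a carboxylic acid, a dimethylamino group or a longer alkoxy chain, would also stay within the scatter remains open, as does whether the same exchange would behave alike on the core of compound 1. Nothing available bears on why amino and methoxy read alike here.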